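This account rests on a few compounds, and the source may have more. Where it says the series, first, only, none or still open, it means among the compounds named here.

Measured in a functional assay on ECa-109 cells (Homo sapiens) for antiproliferative activity, read by MTT assay, with a stated time of 72 h; a higher number here means a weaker inhibitor, a lower number a stronger inhibitor:

- Compound 1 `CCCSc1nc(N/N=C/c2ccc(C)cc2)c2nnn(Cc3ccccc3)c2n1`: > 64000 nM, a limit and not a number
- Compound 2 `CCCSc1nc(N/N=C(\C)c2ccc(O)cc2)c2nnn(Cc3ccccc3)c2n1`: 32500 nM
- Compound 3 `C#CCSc1nc(N/N=C/c2ccc(N(C)C)cc2)c2nnn(Cc3ccccc3)c2n1`: 31300 nM

The values of compound 2 and compound 3 lie within the scatter of each other, so neither ranks ahead. Compound 4 `CCCSc1nc(N/N=C/c2ccc(Cl)cc2)c2nnn(Cc3ccccc3)c2n1` shares everything with compound 2 except one group: a group of 9 heavy atoms (7 carbon, 1 nitrogen, 1 chlorine; one six-membered aromatic ring of carbon only) in place of a group of 10 heavy atoms (8 carbon, 1 nitrogen, 1 oxygen; one six-membered aromatic ring of carbon only), on a nitrogen on an aromatic ring. For the measured compounds named here, only one measured step bears on this, a swap at the same place on the same remaining structure: an at least 1.9-fold lower number from compound 1 to compound 2 (0.29 log units; that floor lies within the scatter). Its floor lies within the scatter, so it supports no firm size or direction. No step beyond the scatter is therefore expected, and the estimated step is a 1.2-fold higher number from compound 2 to compound 4 (0.09 log units; within the scatter). For compound 4 the expected value is 40000 nM, with an estimated range of 15000 nM to 80000 nM.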

Compound 4, half-maximal inhibitory concentration: > 64000 nM
Compound 4 was reported as a limit; the forecaster's own chance of this, stated with the estimate: 40%; middle value at least 1.6-fold (0.20 log units) from the limit.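

Compound 4 is reported only as a limit and not as a number, and compound 1 sits at the same limit: the limit of > 64000 nM in this assay, at which 2 of the 4 values shown sit. The group with chlorine in place of the group with oxygen, on a nitrogen on an aromatic ring, gives an at least 1.9-fold higher number from compound 2 to compound 4 (0.29 log units; that floor lies within the scatter), so this change supports no firm size or direction. The swap of chloro for methyl, from compound 1 to compound 4, cannot be read: both values are limits.

The compounds shown do not separate the oxygen of compound 2 from its extra carbon. On these data alone, how an amine or a carboxylic acid in this group would read also stays open.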